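Fluoro in Place of Hydrogen and Cytotoxicity

The compounds below may be only part of what the source reports. "The series", "measured", "known", "first", "only" and "open" are said of these compounds alone.

Compound 1 `COc1cccc2[nH]cc(C3(c4c[nH]c5cccc(OC)c45)C(=O)Nc4ccccc43)c12` and compound 2 `COc1ccc2[nH]cc(C3(c4c[nH]c5ccc(OC)cc45)C(=O)Nc4ccccc43)c2c1` are built from the same atoms joined differently; the difference between the two cores is not broken down here. In a functional assay on SK-N-SH cells (Homo sapiens) for cytotoxicity, read by MTT assay, with a stated time of 48 h (a lower number here means a stronger inhibitor, a higher number a weaker inhibitor), compound 1 gives 4700 nM, and compound 2 gives 3900 nM, two numbers within the scatter of each other. Compound 3 `COc1cccc2[nH]cc(C3(c4c[nH]c5cccc(OC)c45)C(=O)Nc4ccc(F)cc43)c12` differs from compound 1 by fluoro in place of hydrogen on an aromatic carbon, and in this assay compound 3 gives 12100 nM, a step of a 2.6-fold higher number from compound 1 to compound 3 (0.41 log units; beyond the scatter). Compound 4 `COc1ccc2[nH]cc(C3(c4c[nH]c5ccc(OC)cc45)C(=O)Nc4ccc(F)cc43)c2c1` differs from compound 2 by fluoro in place of hydrogen on an aromatic carbon, the same change at a place described in the same words. The expectation for compound 4 rests on the step of a 2.6-fold higher number from compound 1 to compound 3 (0.41 log units; beyond the scatter) being modest. The step expected in this assay is a 2.4-fold higher number from compound 2 to compound 4 (0.39 log units; beyond the scatter). Compound 4 is therefore estimated at 9500 nM, from 5000 nM to 20000 nM.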

Compound 4, half-maximal inhibitory concentration: 7000 nM
Estimate against measurement, compound 4: 1.4-fold (0.13 log units) above, within the range that was stated.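

In this assay fluoro in place of hydrogen gives a 1.8-fold higher number from compound 2 to compound 4 (0.25 log units; within the scatter) on the core of compound 2, and this step taken alone cannot be told apart from the usual scatter. Set beside the step on the core of compound 1, the change carries over with no difference that can be detected: the same change on two cores in this assay, a 2.6-fold higher number (0.41 log units; beyond the scatter) from compound 1 to compound 3 and a 1.8-fold higher number (0.25 log units; within the scatter) from compound 2 to compound 4, 1.4-fold (0.16 log units) apart, within the scatter of two such steps. Going by these compounds alone, this rests on only two cores, one place and one assay, so it does not show that the change would read the same on any other core, and only the step to compound 3 lies beyond the scatter.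

The compounds shown leave open how chloro, a nitrile or an amine at that same place would read in this assay and whether fluoro elsewhere on the ring would give a step of similar size.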